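Cyclopentyl for ethyl on a piperazine nitrogen: the second trial

This account rests on a few compounds, and the source may have more. Where it says the series, first, only, none or still open, it means among the compounds named here.

Of the compounds shown here, three have been measured in an assay on HEK293 cells for antagonist activity at Toll-like receptor 9 (Homo sapiens), read by spectrophotometry; on this read-out lower numbers stand for stronger inhibition and higher numbers for weaker inhibition. Compound 1 `CCN1CCN(CCCn2cnc3c(N4CCN(CC)CC4)nc(NCc4ccc(N(CC)CC)cc4)nc32)CC1` gives 440 nM. Compound 3 `CCN1CCN(CCCn2cnc3c(N4CCN(C5CCCC5)CC4)nc(NCc4ccc(N(CC)CC)cc4)nc32)CC1` differs from compound 1 in one place, described as cyclopentyl in place of ethyl on an amine nitrogen in a ring, and in this assay compound 3 gives 150 nM; the step is a 2.9-fold lower number from compound 1 to compound 3 (0.47 log units; beyond the scatter). Compound 2 `CCN1CCN(c2nc(N)nc3c2ncn3CCCN2CCCC2)CC1` carries a smaller framework, and the difference between the core of compound 2 and the core of compound 1 is not broken down here; in this assay compound 2 gives 190 nM, which stands within the scatter of the number for compound 3 and beyond the scatter from the number for compound 1.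

Compound 4 `Nc1nc(N2CCN(C3CCCC3)CC2)c2ncn(CCCN3CCCC3)c2n1` has not yet been measured. It differs from compound 2 in one place, described as cyclopentyl in place of ethyl on an amine nitrogen in a ring, and this is the same change that leads from compound 1 to compound 3, made on the same place on the shared piperazine ring. Going by the values given here, only one earlier instance of the change exists, and it sits on a different core, so the expectation rests on a single step. He expects the step from compound 2 to compound 4 to be of similar direction, though somewhat less sure, and estimates it as a 2.4-fold lower number from compound 2 to compound 4 (0.38 log units; beyond the scatter), because the earlier step was a 2.9-fold lower number from compound 1 to compound 3 (0.47 log units; beyond the scatter). He estimates that compound 4 in this assay gives 80 nM, between 30 nM and 250 nM.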

Compound 4, half-maximal inhibitory concentration: 120 nM
Beside the measured number, compound 4's estimate is 1.5-fold (0.18 log units) below it; the range from low to high includes it.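

In this assay, cyclopentyl in place of ethyl on an amine nitrogen in a ring gives a 1.6-fold lower number from compound 2 to compound 4 (0.20 log units; within the scatter), so on the smaller core the step stays inside the usual scatter, whereas on the core of compound 1 it lay beyond it. Set side by side, the two steps cannot be told apart in size: the same change on two cores in this assay, a 2.9-fold lower number (0.47 log units; beyond the scatter) from compound 1 to compound 3 and a 1.6-fold lower number (0.20 log units; within the scatter) from compound 2 to compound 4, 1.9-fold (0.27 log units) apart, within the scatter of two such steps This shows that nothing here separates the behaviour of the change on the two cores, but it does not show that the change has the same effect on both, since the step on the smaller core cannot be read as a real change on its own, and two cores are a narrow basis for any rule about the series.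

The compounds shown leave open whether another group on that ring nitrogen, such as isopropyl, cyclohexyl or benzyl, would give a step that stands clear of the scatter on both cores. They also leave open how the change would fare on a core carrying some other group in place of the free amine of compound 2 or the substituted benzylamine of compound 1.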